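Formyl to ethynyl on the exocyclic-methylene terpenoid cores

A few compounds are considered here, and "the series" means these few. Any claim that something is new, unique, unknown or untested is made for them only; others in the source may bear on it.

Working notes on a short cytotoxicity series. Compound 1 `C=C1CC[C@@H](C(C)C)[C@]12CC=C(C=O)CC2` and compound 2 `C=C1CCC[C@]2(C)CCC(C=O)=CC[C@@]12C` share the same atoms joined differently; the difference between the two cores is not broken down here. In a functional assay on MCF7 cells (Homo sapiens) for cytotoxicity, read by MTT assay, with a stated time of 48 h (on this read-out lower numbers stand for stronger inhibition and higher numbers for weaker inhibition), compound 1 gives 210000 nM and compound 2 gives 319000 nM; these two numbers lie within the scatter of each other, so no order between them is claimed. Compound 3 `C#CC1=CC[C@@]2(C)C(=C)CCC[C@]2(C)CC1` gives 575000 nM in this assay.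

Within the data shown here, the one change already measured is ethynyl in place of formyl on a double-bonded ring carbon. Its size is a 1.8-fold higher number from compound 2 to compound 3 (0.26 log units; within the scatter), a step that sits within the usual scatter of repeated measurements. Compound 4 `C#CC1=CC[C@]2(CC1)C(=C)CC[C@H]2C(C)C` carries the same kind of change on the core of compound 1, namely (ethynyl in place of formyl on a double-bonded ring carbon). The surroundings differ: in compound 2 the formyl sits on a seven-membered non-aromatic ring of carbon only, part of a fused or bridged system of two rings, with methyl groups on two ring atoms; in compound 1 it sits on a six-membered non-aromatic ring of carbon only, joined to another ring at one shared atom. The change is therefore the same kind, not the same.

The expectation for compound 4 rests on compound 1 at 210000 nM and on the measured step of a 1.8-fold higher number from compound 2 to compound 3 (0.26 log units; within the scatter): a step of about the same size, a 1.8-fold higher number from compound 1 to compound 4 (0.26 log units; within the scatter), is expected in this assay. Compound 4 is accordingly estimated at 380000 nM, with a range from 200000 nM to 750000 nM; the differing ring around the changed carbon widens the range.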

Compound 4, half-maximal inhibitory concentration: 135000 nM
For compound 4 the middle estimate is 2.8-fold (0.45 log units) above the measured one, outside the stated range (below it).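

In this assay the new step is a 1.6-fold lower number from compound 1 to compound 4 (0.19 log units; within the scatter), so on the core of compound 1 the exchange of formyl for ethynyl gives no change that can be told from repeated measurement. Set beside the earlier step, the exchange does not carry over from one core to the other as a step of fixed size and direction: the same change on two cores in this assay, a 1.8-fold higher number (0.26 log units; within the scatter) from compound 2 to compound 3 and a 1.6-fold lower number (0.19 log units; within the scatter) from compound 1 to compound 4, 2.8-fold (0.45 log units) apart, beyond the scatter of two such steps. What this shows is limited to these two pairs: neither step alone lies beyond the scatter, so neither core gives a firm direction for the change, the gap between the steps is not tied to any one difference between the cores, and two cores support no rule for the series.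

What a carboxylic acid, an amine or a longer chain on the double-bonded ring carbon would give in this assay stays open, as the compounds shown carry only formyl or ethynyl there. Also open, as far as these compounds go, is whether the exchange of formyl for ethynyl on a third core would follow compound 1 and compound 4, compound 2 and compound 3, or neither pair.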